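The compounds below may be only part of what the source reports. "The series", "measured", "known", "first", "only" and "open" are said of these compounds alone.

Measured so far in an assay on FRT cells with Cystic fibrosis transmembrane conductance regulator variant F508del (Homo sapiens) as the target, read by fluorescence, with a stated time of 25 min; on this read-out lower numbers stand for an effect already at smaller amounts and higher numbers for an effect only at larger amounts of compound:

compound 1 `CN1CCN(CCCNc2nc(-c3ccccn3)nc3c2CN(Cc2ccccc2)CC3)CC1` gives 3100 nM
compound 2 `COc1ccc(CN2CCc3nc(-c4ccccn4)nc(NCCCn4ccnc4)c3C2)cc1` gives 200 nM

Going by the values given here, compound 2 holds the lower of the two numbers; compound 1, its nearest neighbour, sits well above it in this assay, and the two differ in more than one place, so no single step between them can be read off.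

Compound 3 `CCN(C(C)=O)C1CCN(c2nc(-c3ccccn3)nc3c2CN(Cc2ccc(OC)cc2)CC3)C1` is not yet measured. It differs from compound 2 in one place: 3-(acetyl(ethyl)amino)pyrrolidin-1-yl in place of (3-(1H-imidazol-1-yl)propyl)amino on an aromatic carbon. Among the compounds with values here, no measured pair in this assay shows a comparable exchange, so the direction of the step is open. The flexible chain with its hydrogen-bond donor gives way to a ring-bound amide without one, and a moderate loss in this assay seems somewhat more likely than a gain. The expected step from compound 2 to compound 3 is a 2.5-fold higher number from compound 2 to compound 3 (0.40 log units; beyond the scatter). Compound 3 is estimated at 500 nM, with a range from 150 nM to 2500 nM.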

Compound 3, half-maximal effective concentration: 300 nM
Estimate against measurement, compound 3: 1.7-fold (0.22 log units) above; the range from low to high includes it.
By their numbers in this assay, from the lowest: compounds 2 and 3 (each within the scatter of the next); then compound 1.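

In this assay, 3-(acetyl(ethyl)amino)pyrrolidin-1-yl in place of (3-(1H-imidazol-1-yl)propyl)amino on this aromatic carbon gives a 1.5-fold higher number from compound 2 to compound 3 (0.18 log units; within the scatter). In this pair, this position tolerates an exchange of the flexible chain for a non-aromatic ring, and neither the hydrogen-bond donor nor the five-membered aromatic ring of the leaving group is needed to keep the number at this level. No measurement on hand explains why the two groups read alike.

Going by these compounds alone, compound 1 differs from compound 2 and from compound 3 in more than one place, so no step to it can be read. As far as these compounds go, how far the acetyl and ethyl groups on the pyrrolidine matter remains open, as does the reading of a carboxylic acid or a longer chain on this carbon.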